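From Methyl to Methoxy on the Hydrazone Aryl Ring

The source may hold more compounds than are shown below. What is called first, only, known or untested is meant among the compounds shown, and "the series" means these compounds.

Compound 2 `CC1=CC[C@@H]([C@@](C)(O)CCCC(C)(C)NC(=S)N/N=C\c2ccc(C)cc2)CC1` and compound 1 `CC1=CC[C@@H]([C@@](C)(O)CCCC(C)(C)NC(=S)N/N=C\c2ccccc2)CC1` share a core and differ only in one substituent on the aromatic ring. In a functional assay on OVCAR-3 cells (Homo sapiens) for cytotoxicity, read by sulforhodamine B assay (a higher number here means a weaker inhibitor of growth, a lower number a stronger inhibitor of growth), compound 1 gives 6970 nM, and compound 2 gives 6020 nM. For the measured compounds named here, the single measured step, a 1.2-fold lower number from compound 1 to compound 2 (0.06 log units; within the scatter), lies within the scatter, so the two numbers cannot be told apart; compound 2 carries the lowest of the two numbers, with compound 1 as its only and nearest neighbour.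

Compound 3 `COc1ccc(/C=N\NC(=S)NC(C)(C)CCC[C@](C)(O)[C@@H]2CC=C(C)CC2)cc1` has not yet been measured. Compared with compound 2 the change is methoxy in place of methyl on an aromatic carbon. Going by the values given here, only one measured step bears on this site, and that step, a 1.2-fold lower number from compound 1 to compound 2 (0.06 log units; within the scatter), was within the scatter; no measured pair shows methoxy itself. The account therefore expects no step beyond the scatter in this assay, and the estimated step of a 1.1-fold lower number from compound 2 to compound 3 (0.04 log units; within the scatter) reflects that. For compound 3 the estimated value in this assay is 5500 nM, with a range from 2500 nM to 12000 nM, centred near compound 2 because of 6020 nM.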

Compound 3, concentration for 50% growth inhibition: 6500 nM
The estimate for compound 3 lay 1.2-fold (0.07 log units) below the measured number, within the range that was stated.
By their numbers in this assay, from the lowest: compounds 2, 3 and 1 (each within the scatter of the next).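

With methoxy in place of methyl, on an aromatic carbon para to a large group, the group entering adds an oxygen and a hydrogen-bond acceptor, yet this assay shows only a 1.1-fold higher number from compound 2 to compound 3 (0.03 log units; within the scatter). The earlier compounds shown here showed only that methyl could not be told apart from hydrogen at this position; methoxy now gives the same picture against hydrogen, with a 1.1-fold lower number from compound 1 to compound 3 (0.03 log units; within the scatter), so all three compounds remain indistinguishable and none of the three groups at this position separates from the others in this assay. Nothing measured here offers an explanation for this flat result, and no supporting data on the compounds accompany it.

Whether this position is insensitive to substitution in general remains open, as hydrogen, methyl and methoxy are the only groups shown there, and an amine, a carboxylic acid or a nitrile on the same aromatic carbon could still move the number beyond the scatter. Since all three compounds carry the same shared core, what the remainder of the structure contributes to growth inhibition also stays unresolved.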